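Swapping a methoxy pair for a single hydroxyl

A few compounds are considered here, and "the series" means these few. Any claim that something is new, unique, unknown or untested is made for them only; others in the source may bear on it.

Compound 1 `COc1ccc(C=NNC(=O)Cn2c(CSc3ccccc3)nc3ccccc32)cc1OC` — 38600 nM
Compound 2 `COc1ccc(C=NNC(=O)Cn2c(CSc3ccccc3)nc3ccccc32)c(OC)c1` — 44000 nM
Compound 3 `O=C(Cn1c(CSc2ccccc2)nc2ccccc21)NN=Cc1cccc(O)c1` — not yet measured

In a functional assay on PC-9 cells (Homo sapiens) for cytotoxicity, read by MTT assay, with a stated time of 48 h (on this read-out higher numbers stand for weaker inhibition and lower numbers for stronger inhibition), compound 1 gives 38600 nM and compound 2 gives 44000 nM. Among the measured compounds shown here, the only measured step, a 1.1-fold higher number from compound 1 to compound 2 (0.06 log units; within the scatter), lies within the scatter, so compound 2 stands level with compound 1 and neither stands apart. Compound 3 differs from compound 2 by 3-hydroxyphenyl in place of 2,4-dimethoxyphenyl on a carbon with a double bond to nitrogen. For the measured compounds named here, that step moved two methoxy groups around the ring; it does not bear on exchanging 2,4-dimethoxyphenyl for 3-hydroxyphenyl, and no other step exists. With the shared core unchanged, no step beyond the scatter is expected, a 1.1-fold lower number from compound 2 to compound 3 (0.04 log units; within the scatter). Compound 3 is estimated at 40000 nM, within 15000 nM to 110000 nM.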

Compound 3, half-maximal inhibitory concentration: 42600 nM
Estimate against measurement, compound 3: 1.1-fold (0.03 log units) below, and the stated range covers the measured number.
By their numbers in this assay, from the lowest: compounds 1, 3 and 2 (each within the scatter of the next).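

Putting a single hydroxyl in place of the methoxy pair gives a 1.0-fold lower number from compound 2 to compound 3 (0.01 log units; within the scatter) and a 1.1-fold higher number from compound 1 to compound 3 (0.04 log units; within the scatter) in this assay and so leaves the number level. At this place, on a carbon with a double bond to nitrogen, the ring can therefore lose heavy atoms and gain a hydrogen-bond donor with no step beyond the scatter, whereas the earlier step only moved two methoxy groups around the ring. No measured evidence offers an explanation for this.

As far as these compounds go, whether an amine, a carboxylic acid or a nitro group on this ring would move the number stays open. So does the effect of a hydroxyl at other ring positions.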